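The source may report more compounds than this note shows. Statements on the series, on what has been measured and on what is new or still open speak of the compounds shown alone.

Compounds measured so far:
compound 1 `CN1[C@@H]2c3[nH]c4ccccc4c3C[C@H]1[C@H](C#N)N1[C@@H](CNC(=O)c3cccc(C(F)(F)F)c3)c3[nH]c4ccccc4c3C[C@@H]21` gives 110 nM in a functional assay on MCF7 cells (Homo sapiens) for cytotoxicity, read by MTT assay, with a stated time of 72 h; on this read-out higher numbers stand for weaker inhibition and lower numbers for stronger inhibition
compound 2 `CN1[C@@H]2c3[nH]c4ccccc4c3C[C@H]1[C@H](C#N)N1[C@@H](CNC(=O)c3cc4ccccc4s3)c3[nH]c4ccccc4c3C[C@@H]21` gives 3180 nM
compound 3 `CN1[C@@H]2c3[nH]c4ccccc4c3C[C@H]1[C@H](C#N)N1[C@@H](CNC(=O)c3cc4ccccc4[nH]3)c3[nH]c4ccccc4c3C[C@@H]21` gives 9780 nM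

Compound 1 holds the lowest number of the three, and its steps to the other two are both well beyond the scatter, so on this read-out it is the strongest of the measured set. Compound 4 `COc1ccc(/C=C/C(=O)NC[C@H]2c3[nH]c4ccccc4c3C[C@H]3[C@H]4c5[nH]c6ccccc6c5C[C@@H]([C@H](C#N)N23)N4C)cc1` has not yet been tested. It differs from compound 1 in one place: 2-(4-methoxyphenyl)ethenyl in place of 3-(trifluoromethyl)phenyl on a carbonyl carbon

The two measured steps that bear on this change both replace the 3-(trifluoromethyl)phenyl on the carbonyl carbon with another group. Both were large losses: a 29-fold higher number from compound 1 to compound 2 (1.46 log units; beyond the scatter) and an 89-fold higher number from compound 1 to compound 3 (1.95 log units; beyond the scatter). The 2-(4-methoxyphenyl)ethenyl entering in compound 4 is not a bicyclic group like those in compound 2 and compound 3, so a direct comparison is lacking, but the data show that leaving the 3-(trifluoromethyl)phenyl has so far cost potency each time. A weakening step is therefore expected, estimated as a 9.1-fold higher number from compound 1 to compound 4 (0.96 log units; beyond the scatter), though smaller than those seen. Compound 4 is estimated at 1000 nM, with a range from 250 nM to 5000 nM.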

Compound 4, half-maximal inhibitory concentration: 4220 nM
Beside the measured number, compound 4's estimate is 4.2-fold (0.63 log units) below it; the range from low to high includes it.
By their numbers in this assay, from the lowest: compound 1; then compounds 2 and 4 (each within the scatter of the next); then compound 3.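

In this assay, the change to 2-(4-methoxyphenyl)ethenyl keeps one six-membered aromatic ring of carbon only on the carbonyl carbon, yet it still gives a 38-fold higher number from compound 1 to compound 4 (1.58 log units; beyond the scatter), so keeping such a ring does not preserve the low number of compound 1. The result is a 1.3-fold higher number from compound 2 to compound 4 (0.12 log units; within the scatter), which leaves this group and 1-benzothiophen-2-yl indistinguishable here, while a 2.3-fold lower number from compound 3 to compound 4 (0.37 log units; beyond the scatter) separates it modestly from 1H-indol-2-yl. Nothing available explains these differences.

From the compounds shown here alone, it remains open whether the low number of compound 1 depends on the trifluoromethyl group, on the phenyl attached directly to the carbonyl carbon, or on both. Plain phenyl, 3-chlorophenyl and 2-(3-(trifluoromethyl)phenyl)ethenyl at this position would help separate these possibilities.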